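Working notes: replacing the 4-(pentan-3-yl)piperazin-1-yl group

The compounds below may be only part of what the source reports. "The series", "measured", "known", "first", "only" and "open" are said of these compounds alone.

Values measured in a physicochemical assay for solubility, in phosphate buffer, measured as thermodynamic solubility, at pH 2 (on this read-out higher numbers stand for higher solubility and lower numbers for lower solubility), so far
- compound 1 `NC1CCN(c2nc3c(c(Nc4ccc(C(F)(F)F)cc4)n2)CCN(c2ncccc2C(F)(F)F)CC3)C1` gives > 215 ug/mL (a limit)
- compound 2 `CCC(CC)N1CCN(c2nc3c(c(Nc4ccc(C(F)(F)F)cc4)n2)CCN(c2ncccc2C(F)(F)F)CC3)CC1` gives 243 ug/mL (a number)

Going by the values given here, compound 2 at 243 ug/mL holds the only number so far. Compound 1 gives only a limit (the limit of > 215 ug/mL in this assay, at which 1 of the 2 values shown sits) in this assay and no number.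

Compound 3 `CN(c1nc2c(c(Nc3ccc(C(F)(F)F)cc3)n1)CCN(c1ncccc1C(F)(F)F)CC2)C1CCCNC1` is the next case. It carries methyl(piperidin-3-yl)amino in place of 4-(pentan-3-yl)piperazin-1-yl on an aromatic carbon of the shared core (methyl(piperidin-3-yl)amino in place of 4-(pentan-3-yl)piperazin-1-yl on an aromatic carbon).

Among the compounds with values here, only one measured step bears on this change, a step that the limit leaves unreadable from compound 1 to compound 2 in which 4-(pentan-3-yl)piperazin-1-yl replaces 3-aminopyrrolidin-1-yl. It has no readable size and gives no direction. No step beyond the usual scatter is therefore expected in this assay. The anchor is compound 2 at 243 ug/mL alone. The expected size of the step of a 1.0-fold higher number from compound 2 to compound 3 (0.01 log units; within the scatter) is an estimate with wide uncertainty. For compound 3 the expected value is 250 ug/mL with an estimated range of 110 ug/mL to 520 ug/mL. A limit rather than a number is also possible for this compound.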

Compound 3, solubility: > 241 ug/mL
Compound 3: a limit, no number (the forecaster's own chance of this, stated with the estimate: 35%); the middle value lies beyond the limit too.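

In this assay compound 3 gives > 241 ug/mL, a limit and not a number. Going by these compounds alone, no step linking compound 3 to compound 1 or compound 2 can be read. The compounds shown leave open whether methyl(piperidin-3-yl)amino, 3-aminopyrrolidin-1-yl and 4-(pentan-3-yl)piperazin-1-yl differ at all in this assay; only compound 2 holds a number.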